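Naphthoquinone ethers and esters in a HeLa cytotoxicity assay

A few compounds are considered here, and "the series" means these few. Any claim that something is new, unique, unknown or untested is made for them only; others in the source may bear on it.

Measured compounds:
compound 1, `O=C(Oc1ccc2c(c1)C(=O)C=CC2=O)c1ccccc1`, 19200 nM
compound 2, `CC(=O)Oc1ccc2c(c1)C(=O)C=CC2=O`, 27700 nM
compound 3, `O=C1C=CC(=O)c2c(Oc3ccco3)cccc21`, 12500 nM

The read-out throughout is a functional assay on HeLa cells (Homo sapiens) for cytotoxicity; a lower number here means a stronger inhibitor, a higher number a weaker inhibitor. Compound 2 gives the highest of the three numbers. Its nearest neighbour is compound 1 with 19200 nM, a gap within the scatter; the step of a 1.4-fold higher number from compound 1 to compound 2 (0.16 log units; within the scatter) therefore shows that swapping the acyl part of the ester leaves the number essentially unchanged. Compound 3, with its furyl ether on the shared core, gives 12500 nM, a gap from compound 2 beyond the scatter.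

The next compound is compound 4, `CCOc1ccc2c(c1)C(=O)C=CC2=O`. Relative to compound 2 it carries ethyl in place of acetyl on an oxygen on an aromatic ring. For the measured compounds named here, no measured step covers this change directly: the only step in hand, a 1.4-fold higher number from compound 1 to compound 2 (0.16 log units; within the scatter), alters the ester but keeps it, whereas here the ester becomes an ether. Compound 3 shows that an ether on the core can sit somewhat lower than compound 2, but at a different place and with a different group, so it gives only a loose hint.

For compound 4 a step of a 1.4-fold lower number from compound 2 to compound 4 (0.14 log units; within the scatter) is expected, within the scatter. Compound 4 is thus estimated at 20000 nM, with a range from 8000 nM to 50000 nM.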

Compound 4, half-maximal inhibitory concentration: 25100 nM
Beside the measured number, compound 4's estimate is 1.3-fold (0.10 log units) below it, within the range that was stated.
By their numbers in this assay, from the lowest: compounds 3, 1, 4 and 2 (each within the scatter of the next, the first and the last beyond it).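

In this assay, the step of a 1.1-fold lower number from compound 2 to compound 4 (0.04 log units; within the scatter) shows that, on this oxygen on an aromatic ring, acetoxy can give way to ethoxy without a readable change in the number. The ester link is therefore not needed to hold the number at this level, a finding that goes beyond the earlier step of a 1.4-fold higher number from compound 1 to compound 2 (0.16 log units; within the scatter), which only altered the acyl part and kept the ester. No measurement on hand bears on why the number holds across this change.

Still open, as far as these compounds go, is whether a longer chain or a carboxylic acid in place of ethyl on this oxygen would move the number beyond the scatter. Also open, from the compounds shown here alone, is whether an amine in place of ethoxy would leave the number as unchanged as the ethyl group does.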